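Chloro substitution and tolerated concentration in two cores

This account rests on a few compounds, and the source may have more. Where it says the series, first, only, none or still open, it means among the compounds named here.

Compound 1 `Cc1cc(C)cc(Cn2c(=S)[nH]c3ccccc32)c1` and compound 2 `Cc1cc(C)cc(Cn2c(=S)[nH]c3ccc(Cl)cc32)c1` share a core and differ in one place: chloro in place of hydrogen on an aromatic carbon. In an ADME assay on MT4 cells (Homo sapiens) for cytotoxicity (a lower number here means that less compound is tolerated, a higher number that more compound is tolerated), compound 1 gives 5740 nM, while compound 2 gives 305 nM. Among the measured compounds shown here, the step of a 19-fold lower number from compound 1 to compound 2 (1.27 log units; beyond the scatter) is the only measured instance of this change, so the tolerated concentration falls sharply when the chloro enters this core.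

Compound 3 `Cc1cc(C)cc(S(=O)(=O)n2c(SCC(=O)Nc3ccccc3Br)nc3ccccc32)c1` carries a different core; the difference between the core of compound 3 and the core of compound 1 is not broken down here. In this assay compound 3 gives only a limit, >= 235000 nM. This rests on (the limit of >= 235000 nM in this assay, at which 1 of the 3 values shown sits), which leaves the true value of compound 3 unknown beyond that bound.

Compound 4 `Cc1cc(C)cc(S(=O)(=O)n2c(SCC(=O)Nc3ccccc3Br)nc3ccc(Cl)cc32)c1` is yet to be measured in this assay. It differs from compound 3 by chloro in place of hydrogen on an aromatic carbon, the same change as that from compound 1 to compound 2, at the same place on the fused ring. If the change works as it did in the first pair, the tolerated concentration of compound 4 would fall well below that of compound 3; since the starting point for compound 3 is only a limit, the landing point cannot be fixed. The expected step is an at least 4.7-fold lower number from compound 3 to compound 4 (0.67 log units; beyond the scatter), smaller in the number than the measured one because compound 3 sits at >= 235000 nM and may lie far above it. For compound 4 the estimate in this assay is 50000 nM, within 8000 nM to 300000 nM, with a real chance that only a limit is returned.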

Compound 4, half-maximal cytotoxic concentration: 145000 nM
For compound 4 the middle estimate is 2.9-fold (0.46 log units) below the measured one, and the stated range covers the measured number.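

On the core of compound 3, chloro in place of hydrogen on an aromatic carbon gives an at least 1.6-fold lower number from compound 3 to compound 4 (0.20 log units; that floor lies within the scatter) in this assay, so the result does not contradict the direction seen on the core of compound 1, although a floor of this size does not establish that direction on its own. The size of the step on this second core stays unfixed, since its starting point is a limit and not a number: the limit of >= 235000 nM in this assay, at which 1 of the 4 values shown sits. Across the two cores, the series therefore shows a change compatible in direction, but it does not show that the change carries over with the same size, nor that its size depends on the core: the same change on two cores in this assay, a 19-fold lower number (1.27 log units; beyond the scatter) from compound 1 to compound 2 and an at least 1.6-fold lower number (0.20 log units; that floor lies within the scatter) from compound 3 to compound 4; the limit leaves it open whether they differ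

With only one pair on each core, the compounds shown leave open how general the behaviour of the chloro is on either core, and whether a further core would follow the same direction. Also open, on these data alone, is what a methoxy group or an amine in place of the chloro, on that same aromatic carbon, would do to the tolerated concentration on each of the two cores.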